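The source may report more compounds than this note shows. Statements on the series, on what has been measured and on what is new or still open speak of the compounds shown alone.

Measured so far in a functional assay on TK-10 cells (Homo sapiens) for cytotoxicity, read by sulforhodamine B assay, with a stated time of 48 h; a lower number here means that less compound is tolerated, a higher number that more compound is tolerated: compound 1 `ClCc1ccccc1Cn1cnc2c(Cl)nc(Cl)nc21` gives 5620 nM; compound 2 `ClCc1ccccc1Cn1cnc2c(Cl)ncnc21` gives 95500 nM.

Compound 2 holds the highest of the two numbers in this assay, the nearest being compound 1 at a 17-fold higher number from compound 1 to compound 2 (1.23 log units; beyond the scatter). Compound 3 `Nc1nc(Cl)c2ncn(Cc3ccccc3CCl)c2n1` arises from compound 2 by amino in place of hydrogen on an aromatic carbon, on an aromatic carbon between two ring nitrogen atoms of the core. Among the measured compounds shown here, the only measured step, a 17-fold higher number from compound 1 to compound 2 (1.23 log units; beyond the scatter), shows that this carbon matters but concerns a different group, so it bears only indirectly. A moderate move is therefore expected, a 2.4-fold lower number from compound 2 to compound 3 (0.38 log units; beyond the scatter). Compound 3 is estimated at 40000 nM, range 10000 nM to 160000 nM.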

Compound 3, concentration lethal to 50% of the cells: 75900 nM
The estimate for compound 3 lay 1.9-fold (0.28 log units) below the measured number, within the range that was stated.
By their numbers in this assay, from the lowest: compound 1; then compounds 3 and 2 (each within the scatter of the next).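

In this assay, amino on the aromatic carbon between two ring nitrogen atoms gives a 1.3-fold lower number from compound 2 to compound 3 (0.10 log units; within the scatter) and so does not separate from hydrogen at this carbon. Amino in place of chloro gives a 14-fold higher number from compound 1 to compound 3 (1.13 log units; beyond the scatter) in the same direction as hydrogen in place of chloro, so among the three groups shown, only chloro stands apart. No measurement available here explains this difference. Still open, going by these compounds, is whether a methyl, methoxy or dimethylamino group at this carbon would fall with chloro or with hydrogen and amino.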